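The source may hold more compounds than are shown below. What is called first, only, known or untested is meant among the compounds shown, and "the series" means these compounds.

Measured so far in a toxicity assay on the whole organism (strain Icem-CET (SPF Caw)) for cytotoxicity, with Mus musculus as the target; on this read-out higher numbers stand for an effect only at larger amounts of compound and lower numbers for an effect already at smaller amounts:
- compound 1 `C/C(C(=O)NC1CC1)=C(/C)c1ccccc1` gives 100 mg/kg
- compound 2 `C#CCNC(=O)/C(C)=C(\C)c1ccc(C)cc1` gives 120 mg/kg
- compound 3 `C/C(C(=O)NC1CC1)=C(/C)c1ccc(Cl)cc1` gives 350 mg/kg

Compound 3 stands highest of the three in this assay, clearly apart from compound 2 and compound 1. Among the measured compounds shown here, the one measured step that bears on the next change is the one in which chloro entered: a 3.5-fold higher number from compound 1 to compound 3 (0.54 log units; beyond the scatter). Compound 4 `C/C(C(=O)NC1CC1)=C(/C)c1ccc(C)cc1` now carries methyl in place of chloro on an aromatic carbon. For the measured compounds named here, no measured pair isolates methyl against chloro, but compound 2, which bears methyl on its ring, sits near compound 1 rather than near compound 3. It is therefore expected that some of the rise seen on going to compound 3 is given back, and compound 4 is estimated at 150 mg/kg (range 80 mg/kg to 300 mg/kg), meaning an expected step of a 2.3-fold lower number from compound 3 to compound 4 (0.37 log units; beyond the scatter).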

Compound 4, dose for half-maximal effect: 110 mg/kg
Compound 4: the middle estimate sits 1.4-fold (0.13 log units) above what was measured; the measured number falls inside the stated range.
By their numbers in this assay, from the lowest: compounds 1, 4 and 2 (each within the scatter of the next); then compound 3.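

In this assay, the ring carbon para to a large group responds to what sits on it, but not to every change: with methyl in place of chloro there is a 3.2-fold lower number from compound 3 to compound 4 (0.50 log units; beyond the scatter), whereas with methyl in place of hydrogen there is only a 1.1-fold higher number from compound 1 to compound 4 (0.04 log units; within the scatter). With the methyl ring kept, cyclopropyl in place of propargyl on the amide nitrogen gives a 1.1-fold lower number from compound 2 to compound 4 (0.04 log units; within the scatter), so this swap does not register either. Nothing available explains why chloro stands apart from methyl and hydrogen here.

Going by these compounds, it remains open whether the rise belongs to chloro alone or would also appear with bromo, methoxy or an amine at this position. On these data alone, it is also open whether propargyl and cyclopropyl would still read alike with chloro on the ring.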